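Bromo for Nitro on the Aryl Ring of Compound 1

The source may report more compounds than this note shows. Statements on the series, on what has been measured and on what is new or still open speak of the compounds shown alone.

Among the measured compounds shown here, compound 1 `O=c1c2cc([N+](=O)[O-])cnc2sn1-c1ccc([N+](=O)[O-])cc1` is the only member of this small group with a number: in an assay for inhibition of histone acetyltransferase KAT2B (Homo sapiens), read by fluorescence (on this read-out lower numbers stand for stronger inhibition and higher numbers for weaker inhibition), compound 1 gives 15800 nM. A second compound, compound 2 `Oc1nsc2ncccc12`, in this assay gives "not determined" (no result reported), so compound 1 stands alone and cannot be ranked against anything.

Compound 3 `O=c1c2cc([N+](=O)[O-])cnc2sn1-c1ccc(Br)cc1` keeps the shared core of compound 1 and changes one place: bromo in place of nitro on an aromatic carbon. For the measured compounds named here, no pair of measured compounds shows what such a change does here, so the expectation rests on compound 1 alone and on the size of the change. The group that leaves is replaced by a single heavy atom, and nothing in the data says whether this should help or hurt.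

Compound 3 is therefore expected to sit close to compound 1, with a step of a 1.3-fold higher number from compound 1 to compound 3 (0.10 log units; within the scatter) that is not expected to go beyond the usual scatter in either direction. The estimate for compound 3 in this assay is 20000 nM, within a range from 6000 nM to 60000 nM.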

Compound 3, half-maximal inhibitory concentration: 860 nM
Beside the measured number, compound 3's estimate is 23-fold (1.37 log units) above it, and the stated range ends above it.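

In this assay, bromo in place of nitro on an aromatic carbon para to a large group gives an 18-fold lower number from compound 1 to compound 3 (1.26 log units; beyond the scatter) and so counts as a large step, beyond the scatter. Compound 1 alone could not show this: the place on the six-membered aromatic ring of carbon only is not indifferent to the group it carries, and a single bromine atom in place of the three heavy atoms of nitro goes with stronger inhibition. No measured property bears on this result, and the data give no cause for the step.

With one swap at this place, the compounds shown cannot separate what bromo itself contributes from what the loss of nitro contributes. As far as these compounds go, it remains open whether chloro, a methyl group, an amine or a carboxylic acid at the same place would keep, enlarge or lose the step, and whether the step would hold if the nitro group on the shared core were changed as well.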